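Ethynyl for Thiophenyl on Two Nucleoside Cores

This account rests on a few compounds, and the source may have more. Where it says the series, first, only, none or still open, it means among the compounds named here.

In a functional assay on K562 cells (Homo sapiens), read by MTT assay, with a stated time of 72 h (on this read-out lower numbers stand for stronger inhibition and higher numbers for weaker inhibition), compound 1 `C#Cc1cn([C@@H]2O[C@H](CO)[C@@H](O)[C@H]2O)c2ncnc(C)c12` gives 6920 nM. Compound 3 `Cc1ncnc2c1c(-c1cccs1)cn2[C@@H]1O[C@H](CO)[C@@H](O)[C@H]1O` differs from it only in the group on the five-membered ring. In this assay compound 3 is reported at a limit of the assay, > 20000 nM. The change ethynyl in place of thiophen-2-yl on an aromatic carbon thus brings an at least 2.8-fold lower number from compound 3 to compound 1 (0.46 log units; beyond the scatter), a step whose size rests on (the limit of > 20000 nM in this assay, at which 2 of the 3 values shown sit), where compound 3 sits. Compound 2 `COc1nc(N)nc2c1c(-c1cccs1)cn2[C@@H]1O[C@H](CO)[C@@H](O)[C@H]1O` carries the same thiophen-2-yl group on another core; the difference between the cores of compound 2 and compound 3 is not broken down here. In this assay compound 2 likewise reaches only a limit of the assay, > 20000 nM. Compound 4 `C#Cc1cn([C@@H]2O[C@H](CO)[C@@H](O)[C@H]2O)c2nc(N)nc(OC)c12` has not yet been measured in this assay; it arises from compound 2 by ethynyl in place of thiophen-2-yl on an aromatic carbon, the same change as that between compound 3 and compound 1, at a place described in identical words. Compound 2 stands at a limit, and the earlier step gives a direction rather than a fixed size. The step from compound 2 to compound 4 is expected to be an at least 2.0-fold lower number from compound 2 to compound 4 (0.30 log units; that floor lies within the scatter), resting on the step of an at least 2.8-fold lower number from compound 3 to compound 1 (0.46 log units; beyond the scatter) seen with compound 3 and compound 1. For compound 4 the estimate in this assay is 10000 nM, between 3000 nM and 30000 nM, with a real chance that only a limit is again reported.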

Compound 4, half-maximal inhibitory concentration: > 20000 nM
Compound 4 ended at the assay's limit; the forecaster's own chance of this, stated with the estimate: 35%; at least 2.0-fold (0.30 log units) between middle value and limit.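

Compound 4 is reported only at a limit of this assay, as is compound 2, so no step between these two compounds can be read: the limit of > 20000 nM in this assay, at which 3 of the 4 values shown sit.

The compounds shown leave open whether ethynyl in place of thiophen-2-yl on an aromatic carbon lowers the number at all on the core shared by compound 2 and compound 4.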